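Bromo for methoxy on the fused ring of compound 3

A few compounds are considered here, and "the series" means these few. Any claim that something is new, unique, unknown or untested is made for them only; others in the source may bear on it.

Measured so far in a functional assay for inhibition, with a stated time of 30 min, tested at 1 mM; on this read-out higher numbers stand for more inhibition at the one concentration tested (going by the name of the read-out) and lower numbers for less inhibition:
- compound 1 `COc1ccc(/C(Cl)=C/C=C(\C#N)C(=O)c2c[nH]c3ccc(Br)cc23)cc1OC` gives 11.8%
- compound 2 `N#C/C(=C\C=C(/Cl)c1ccc(Br)cc1)C(=O)c1c[nH]c2ccc(Br)cc12` gives 15.8%
- compound 3 `COc1ccc(/C(Cl)=C/C=C(\C#N)C(=O)c2c[nH]c3ccc(OC)cc23)cc1` gives 16.7%

On the numbers shown, compound 3 stands at the top of the three, but its gap to compound 2 and its gap to compound 1 both lie within the usual scatter of this assay, so the three compounds are not separated by these readings. No two of them differ in one place only, so no single step can be read off.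

Compound 4 `COc1ccc(/C(Cl)=C/C=C(\C#N)C(=O)c2c[nH]c3ccc(Br)cc23)cc1` is the partner of compound 3 in which the change is bromo in place of methoxy on an aromatic carbon

Compound 1 and compound 2 already carry bromo rather than methoxy at this aromatic carbon of the fused system, and in this assay compound 1 gives 11.8% while compound 2 gives 15.8%, both within the scatter of compound 3. The step is therefore expected to be none beyond the scatter, a number 2.7 percentage points lower from compound 3 to compound 4 (within the scatter), in this assay. Compound 4 is expected to give 14%, with a range from 5% to 25%.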

Compound 4, a percentage reported as inhibition, at one concentration (the size of the read-out at that concentration, not a potency): 15.6%
Compound 4: the middle estimate sits 1.6 percentage points below what was measured; low and high end bracket the measured number.
By their numbers in this assay, from the lowest: compounds 1, 4, 2 and 3 (each within the scatter of the next).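

In this assay, among the compounds shown here, bromo in place of methoxy on the aromatic carbon of the fused system gives a number 1.1 percentage points lower from compound 3 to compound 4 (within the scatter), the first one-place comparison at this position, and the exchange leaves the reading within the scatter. Two further one-place changes on an aromatic carbon read the same way: methoxy in place of bromo gives a number 0.2 percentage points lower from compound 2 to compound 4 (within the scatter), and hydrogen in place of methoxy gives a number 3.8 percentage points higher from compound 1 to compound 4 (within the scatter). Nothing at hand bears on why these readings lie so close together.

Open, as far as these compounds go, is whether any group on this aromatic carbon moves the reading beyond the scatter, for example an amine or a carboxylic acid in place of methoxy or bromo. All four readings come from one concentration, and they give no potency for any of these compounds.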